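Swapping one five-membered heterocycle on two cores

A few compounds are considered here, and "the series" means these few. Any claim that something is new, unique, unknown or untested is made for them only; others in the source may bear on it.

Compound 1 `Cc1ccc(C2CNN=C2S(=O)(=O)CC2=NCCS2)cc1` and compound 3 `Cc1ccc(C2CNN=C2S(=O)(=O)CC2=NCCO2)cc1` share a core and differ only in that (a group of 5 heavy atoms (3 carbon, 1 nitrogen, 1 oxygen; one five-membered non-aromatic ring with 2 hetero atoms) in place of a group of 5 heavy atoms (3 carbon, 1 nitrogen, 1 sulfur; one five-membered non-aromatic ring with 2 hetero atoms), on a saturated chain carbon bound to a sulfonyl sulfur). In a functional assay, tested at 75 ug/mL (on this read-out higher numbers stand for a stronger effect at the one concentration tested and lower numbers for a weaker effect), compound 1 gives 42.2% and compound 3 gives 42.1%, so the step of a number 0.1 percentage points lower from compound 1 to compound 3 (within the scatter). Compound 2 `O=S(=O)(CC1=NCCS1)c1c(-c2ccccc2)noc1-c1ccccc1` is built on a second core; how the two cores differ is not broken down here. In this assay compound 2 is reported as "not active" (no number reported), with no number given. Compound 4 `O=S(=O)(CC1=NCCO1)c1c(-c2ccccc2)noc1-c1ccccc1` relates to compound 2 in that (a group of 5 heavy atoms (3 carbon, 1 nitrogen, 1 oxygen; one five-membered non-aromatic ring with 2 hetero atoms) in place of a group of 5 heavy atoms (3 carbon, 1 nitrogen, 1 sulfur; one five-membered non-aromatic ring with 2 hetero atoms), on a saturated chain carbon bound to a sulfonyl sulfur), the same change seen between compound 1 and compound 3. Because the step of a number 0.1 percentage points lower from compound 1 to compound 3 (within the scatter), and because compound 2 gave "not active" (no number reported), a step of about the same size, within the scatter, is expected on going from compound 2 to compound 4. Compound 4 is therefore expected to read about 5% in this assay, probably again without a number, within an estimated range of 0% to 20%.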

Compound 4, a percentage reported as activity, at one concentration (the size of the read-out at that concentration, not a potency): 58.1%
Estimate against measurement, compound 4: 53.1 percentage points below; the measured number lies above the stated range.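

In this assay compound 4 gives 58.1% but compound 2 has no number, so no step can be read between them. The size of the ring swap on this core stays open, and nothing shown here offers an explanation.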